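A few compounds are considered here, and "the series" means these few. Any claim that something is new, unique, unknown or untested is made for them only; others in the source may bear on it.

Of the compounds shown here, three built on one shared core have been tested in a functional assay on A549 cells (Homo sapiens) for cytotoxicity, read by MTT assay, with a stated time of 72 h; on this read-out lower numbers stand for stronger inhibition and higher numbers for weaker inhibition. Compound 1 `CN(C)CCn1cnnc1-c1cc(Oc2ccc(NC(=O)N/N=C/c3ccc(Cl)cc3Cl)cc2F)ccn1` gives 810 nM, compound 2 `CN(C)CCn1cnnc1-c1cc(Oc2ccc(NC(=O)N/N=C/c3ccc(F)cc3)cc2F)ccn1` gives 1790 nM, and compound 3 `CN(C)CCn1cnnc1-c1cc(Oc2ccc(NC(=O)N/N=C/c3c(O)ccc4ccccc34)cc2F)ccn1` gives 880 nM. Among the compounds with values here, on these numbers compound 3 stands second highest of the three: its value lies within the scatter of that of compound 1, and only the step of a 2.0-fold lower number from compound 2 to compound 3 (0.31 log units; beyond the scatter) sets it apart from the others.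

Compound 4 `CN(C)CCn1cnnc1-c1cc(Oc2ccc(NC(=O)N/N=C/c3ccc(F)cc3Cl)cc2F)ccn1` has not yet been measured. It differs from compound 3 in a single place: 2-chloro-4-fluorophenyl in place of 2-hydroxynaphthalen-1-yl on a carbon with a double bond to nitrogen. Within the data shown here, two measured steps bear on this change. The step of a 1.1-fold higher number from compound 1 to compound 3 (0.04 log units; within the scatter) stayed within the scatter, whereas the step of a 2.0-fold lower number from compound 2 to compound 3 (0.31 log units; beyond the scatter) was modest but beyond it. The entering group shares a chlorine with the 2,4-dichlorophenyl of compound 1 and a fluorine with the 4-fluorophenyl of compound 2, so a number between those two compounds is expected. In this assay the expected step is a 1.3-fold higher number from compound 3 to compound 4 (0.10 log units; within the scatter), a small rise that should stay within the scatter. Compound 4 is therefore estimated at 1100 nM, with a likely range from 500 nM to 2500 nM.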

Compound 4, half-maximal inhibitory concentration: 1120 nM
For compound 4 the middle estimate is 1.0-fold (0.01 log units) below the measured one; the measured number falls inside the stated range.
By their numbers in this assay, from the lowest: compounds 1, 3, 4 and 2 (each within the scatter of the next, the first and the last beyond it).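

In this assay, replacing 2-hydroxynaphthalen-1-yl with 2-chloro-4-fluorophenyl on the carbon with a double bond to nitrogen removes a six-membered aromatic ring and the hydrogen-bond donor, yet it gives only a 1.3-fold higher number from compound 3 to compound 4 (0.10 log units; within the scatter), so for this pair neither feature is needed to keep the number within the scatter. Compound 4 also links the two halogenated compounds through single-atom changes: chloro in place of hydrogen on an aromatic carbon gives a 1.6-fold lower number from compound 2 to compound 4 (0.20 log units; within the scatter), and fluoro in place of chloro on an aromatic carbon gives a 1.4-fold higher number from compound 1 to compound 4 (0.14 log units; within the scatter), so the gap between compound 1 and compound 2, which is beyond the scatter, splits into two steps that each stay within it. Nothing available here explains why these changes have the size they do.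

The compounds shown leave open whether the hydroxyl or the second ring of 2-hydroxynaphthalen-1-yl could be removed separately with the same outcome. They also do not show how the number would respond to an amine or a carboxylic acid on the phenyl ring, or to a longer alkyl chain in place of that ring.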